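The source may hold more compounds than are shown below. What is called first, only, known or untested is meant among the compounds shown, and "the series" means these compounds.

Compound 1 `O=C1NS(=O)(=O)N(COCCO)c2ccccc21` and compound 2 `CC(=O)OCCOCN1c2ccccc2C(=O)N(Cc2ccccc2)S1(=O)=O` are built on the shared core. In a functional assay on HEL cells (Homo sapiens) (a higher number here means that more compound is tolerated, a lower number that less compound is tolerated), compound 1 gives 112 ug/mL. In this assay compound 2 gives 100 ug/mL. Compound 3 `C#CCOCN1c2ccccc2C(=O)N(Cc2ccccc2)S1(=O)=O` stands only at a limit of this assay, > 50 ug/mL. Because of the limit of > 50 ug/mL in this assay, at which 1 of the 3 values shown sits, the step that the limit leaves unreadable from compound 2 to compound 3 cannot be read. Compound 4 `O=C1c2ccccc2N(COCCO)S(=O)(=O)N1Cc1ccccc1` differs from compound 3 by hydroxymethyl in place of ethynyl on a saturated chain carbon bound to an oxygen on a saturated carbon. No readable measured step bears on this change, so its size and direction in this assay cannot be taken from the steps shown. Compound 1, which also carries hydroxymethyl at that place, gives 112 ug/mL, and compound 2 gives 100 ug/mL, values within the scatter of each other. Compound 4 is therefore expected near 105 ug/mL, between 50 ug/mL and 200 ug/mL. The step this estimate means is a step that the limit leaves unreadable from compound 3 to compound 4.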

Compound 4, half-maximal cytotoxic concentration: 125 ug/mL
Compound 4: middle estimate off by 1.2-fold (0.08 log units), on the low side, and the stated range covers the measured number.
By their numbers in this assay, from the lowest: compounds 2, 1 and 4 (each within the scatter of the next).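

With hydrogen in place of acetyl on the oxygen, this assay shows a 1.3-fold higher number from compound 2 to compound 4 (0.10 log units; within the scatter) and so no readable effect of that change. Benzyl in place of hydrogen on the amide-type nitrogen gives a 1.1-fold higher number from compound 1 to compound 4 (0.05 log units; within the scatter) and likewise has no readable effect, so compounds 1, 2 and 4 do not separate here. The step from the ethynyl compound 3 to compound 4 cannot be read: the limit of > 50 ug/mL in this assay, at which 1 of the 4 values shown sits.

Going by these compounds, what an amine or a carboxylic acid would do at the end of the chain remains open. On these data alone, a longer chain also remains open.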